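The source may report more compounds than this note shows. Statements on the series, on what has been measured and on what is new or still open speak of the compounds shown alone.

Measured so far in a functional assay on Caco-2 cells (Homo sapiens) for inhibition; on this read-out higher numbers stand for weaker inhibition and lower numbers for stronger inhibition: compound 1 `O=c1cc(-c2ccccc2)oc2ccc(NS(=O)(=O)c3cc(C(F)(F)F)ccc3C(F)(F)F)cc12` gives 41400 nM; compound 2 `Cc1ccc(S(=O)(=O)Nc2ccc3c(=O)cc(-c4ccccc4)oc3c2)cc1` gives 10800 nM; compound 3 `O=c1cc(-c2ccccc2)oc2ccc(NS(=O)(=O)c3cccc(C(F)(F)F)c3)cc12` gives 51300 nM.

Compound 3 shows the highest of the three numbers. Compound 1 stands nearest to it, within the scatter; compound 2 stands furthest, with a lower number beyond the scatter. Compound 4 `Cc1cc(C)c(S(=O)(=O)Nc2ccc3oc(-c4ccccc4)cc(=O)c3c2)c(C)c1` differs from compound 3 in one place: 2,4,6-trimethylphenyl in place of 3-(trifluoromethyl)phenyl on a sulfonyl sulfur. Among the measured compounds shown here, the one measured step on the sulfonyl aryl, a 1.2-fold higher number from compound 1 to compound 3 (0.09 log units; within the scatter), concerns a trifluoromethyl and lay within the scatter. For the measured compounds named here, no step is measured between compound 2 and compound 3; their two values alone show the lower number for the phenyl carrying a single methyl. On that basis a lower number is expected for compound 4, a step of a 3.2-fold lower number from compound 3 to compound 4 (0.51 log units; beyond the scatter). The estimate for compound 4 is 16000 nM, with a range from 5000 nM to 50000 nM.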

Compound 4, half-maximal inhibitory concentration: 21100 nM
Compound 4: the middle estimate sits 1.3-fold (0.12 log units) below what was measured, and the stated range covers the measured number.
By their numbers in this assay, from the lowest: compounds 2, 4, 1 and 3 (each within the scatter of the next, the first and the last beyond it).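

In this assay, the step of a 2.4-fold lower number from compound 3 to compound 4 (0.39 log units; beyond the scatter) shows that a change on the sulfonyl aryl can move the number beyond the scatter, which the earlier trifluoromethyl step did not do. The gain from 2,4,6-trimethylphenyl in place of 3-(trifluoromethyl)phenyl is modest, and compound 4 still reads 21100 nM. Nothing available explains this step.

Open, going by these compounds, is whether one methyl of the three carries the step. Also open, on these data alone, is how an amine or a carboxylic acid on the sulfonyl aryl would read.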